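The source may hold more compounds than are shown below. What is called first, only, known or untested is meant among the compounds shown, and "the series" means these compounds.

Three close relatives have been measured in a functional assay on HeLa cells (Homo sapiens) for inhibition, read by MTT assay, with a stated time of 72 h; a higher number here means a weaker inhibitor, a lower number a stronger inhibitor. Compound 3 `CN(C(=O)NC(=O)c1ccc(F)c(F)c1)c1nc(C(F)(F)F)c(C(=O)N/N=C/c2cc(C(F)(F)F)cc(C(F)(F)F)c2)s1` gives 4.45 ug/mL, the lowest of the three numbers. Compound 2 `CN(C(=O)NC(=O)c1ccccc1F)c1nc(C(F)(F)F)c(C(=O)N/N=C/c2cc(C(F)(F)F)cc(C(F)(F)F)c2)s1` gives 4.98 ug/mL, which lies within the scatter of compound 3, so the two cannot be told apart. Compound 1 `CN(C(=O)NC(=O)c1ccc(Cl)cc1Cl)c1nc(C(F)(F)F)c(C(=O)N/N=C/c2cccc(C(F)(F)F)c2)s1` gives 9.6 ug/mL, a number beyond the scatter above compound 3.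

The step to compound 4 `CN(C(=O)NC(=O)c1ccc(Cl)cc1Cl)c1nc(C(F)(F)F)c(C(=O)N/N=C/c2cc(C(F)(F)F)cc(C(F)(F)F)c2)s1` is 2,4-dichlorophenyl in place of 3,4-difluorophenyl on a carbonyl carbon. Among the compounds with values here, only one measured step touches the same place: a 1.1-fold lower number from compound 2 to compound 3 (0.05 log units; within the scatter), where one fluorinated phenyl replaced another and the number barely moved. Within the data shown here, compound 1 carries the same 2,4-dichlorophenyl group that enters in compound 4, yet it also differs from compound 4 in another part of the molecule, so no single-change step links the two and its higher number cannot be attributed to the dichlorophenyl alone. Among the measured compounds shown here, the one relevant step thus says that swapping halogenated phenyls at this carbonyl carbon changes little, while compound 1 hints that the dichlorophenyl may sit somewhat higher.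

On this basis compound 4 is expected to show a 1.3-fold higher number from compound 3 to compound 4 (0.13 log units; within the scatter), a move that may stay within the scatter. The estimate for compound 4 is 6 ug/mL, with a likely range from 3 ug/mL to 12 ug/mL.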

Compound 4, half-maximal inhibitory concentration: > 100 ug/mL
Compound 4 ended at the assay's limit; the forecaster's own chance of this, stated with the estimate: 3%; middle value at least 16-fold (1.22 log units) away from the limit.
By their numbers in this assay, from the lowest: compounds 3, 2 and 1 (each within the scatter of the next, the first and the last beyond it). At a limit, above all of these: compound 4.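

In this assay compound 4 gives > 100 ug/mL, which is a limit of the assay and not a number, so each step into it gives only a minimum size: the limit of > 100 ug/mL in this assay, at which 1 of the 4 values shown sits. The earlier step, a 1.1-fold lower number from compound 2 to compound 3 (0.05 log units; within the scatter), made this carbonyl carbon look tolerant of one halogenated phenyl replacing another, but that does not hold for every such swap: 2,4-dichlorophenyl in place of 3,4-difluorophenyl gives an at least 22-fold higher number from compound 3 to compound 4 (1.35 log units; beyond the scatter), and 2,4-dichlorophenyl in place of 2-fluorophenyl gives an at least 20-fold higher number from compound 2 to compound 4 (1.30 log units; beyond the scatter). The 2,4-dichlorophenyl group alone does not bring a compound to the limit, since compound 1 carries it and still gives a measured number, while trifluoromethyl in place of hydrogen on an aromatic carbon gives an at least 10-fold higher number from compound 1 to compound 4 (1.01 log units; beyond the scatter), so the outcome at one place depends on what sits at the other.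

Still open, on these data alone, is whether the chlorines themselves or their placement on the ring matter more, a question that a 2,4-difluorophenyl or a 3,4-dichlorophenyl group on the same carbonyl carbon could settle. Also open, as far as these compounds go, is how a phenyl carrying an amine or a carboxylic acid would behave at this position.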